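Swapping an Amide for a Boron-Bearing Group

A few compounds are considered here, and "the series" means these few. Any claim that something is new, unique, unknown or untested is made for them only; others in the source may bear on it.

Measured in a functional assay on HeLa cells (Homo sapiens) for antiproliferative activity, read by CCK-8 assay, with a stated time of 72 h; on this read-out higher numbers stand for weaker inhibition and lower numbers for stronger inhibition:
Compound 1 `CCOc1ccc(-c2cncnc2-c2cc(OC)c(OC)c(OC)c2)cc1` gives 250 nM
Compound 2 `CNC(=O)c1ccc(-c2cncnc2-c2cc(OC)c(OC)c(OC)c2)cc1` gives 1470 nM
Compound 3 `COc1cc(-c2ncncc2-c2ccc(C(=O)N(C)C)cc2)cc(OC)c1OC` gives 790 nM

The two amides stay close, with a 1.9-fold lower number from compound 2 to compound 3 (0.27 log units; within the scatter) as their gap. Compound 3 therefore shares the weaker end of this small set with compound 2. Replacing ethoxy with either amide weakens inhibition, with a 5.9-fold higher number from compound 1 to compound 2 (0.77 log units; beyond the scatter) and a 3.2-fold higher number from compound 1 to compound 3 (0.50 log units; beyond the scatter) as the measured steps. Compound 4 `COc1cc(-c2ncncc2-c2ccc(B(O)O)cc2)cc(OC)c1OC` differs from compound 3 by a group of 3 heavy atoms (1 boron, 2 oxygen; no ring) in place of a group of 5 heavy atoms (3 carbon, 1 nitrogen, 1 oxygen; no ring), on an aromatic carbon and has not been measured. For the measured compounds named here, no measured step tests the new group, so the expected size rests on a 3.2-fold higher number from compound 1 to compound 3 (0.50 log units; beyond the scatter) as a guide: a modest step at most, in either direction. The estimated step is a 1.2-fold lower number from compound 3 to compound 4 (0.08 log units; within the scatter) in this assay with no clear direction expected. Compound 4 is estimated at 650 nM with an expected range from 150 nM to 2500 nM overall.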

Compound 4, half-maximal inhibitory concentration: 4000 nM
Compound 4: middle estimate off by 6.2-fold (0.79 log units), on the low side; measured number above the stated range.
By their numbers in this assay, from the lowest: compound 1; then compounds 3 and 2 (each within the scatter of the next); then compound 4.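

In this assay, the boron-bearing group weakens inhibition past both amides, with a 5.1-fold higher number from compound 3 to compound 4 (0.70 log units; beyond the scatter) and a 2.7-fold higher number from compound 2 to compound 4 (0.43 log units; beyond the scatter). The same change from ethoxy is a much larger one, with a 16-fold higher number from compound 1 to compound 4 (1.20 log units; beyond the scatter), although ethoxy and the boron-bearing group have the same number of heavy atoms, so the size of the group alone does not set the number at this aromatic carbon. No measurement shown explains this gap.

As far as these compounds go, whether a carboxylic acid, an amine or a longer ether chain at this carbon would fall nearer compound 1 or compound 4 stays open.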